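Extending an Amide Side Chain: From Compound 2 to Compound 3

The source may report more compounds than this note shows. Statements on the series, on what has been measured and on what is new or still open speak of the compounds shown alone.

Compound 1 `CCOC(=O)c1[nH]c(C)c(C(=O)OC2CC3CCC2C3)c1C` gives 100 nM in an assay on CHO cells for inhibition of metabotropic glutamate receptor 1 (Homo sapiens); on this read-out higher numbers stand for weaker inhibition and lower numbers for stronger inhibition.
Compound 2 `COCCNC(=O)c1[nH]c(C)c(C(=O)OC2CC3CCC2C3)c1C` gives 316 nM in this assay.

For the measured compounds named here, compound 2 holds the higher of the two measured numbers; its only neighbour, compound 1, sits below it by a 3.2-fold higher number from compound 1 to compound 2 (0.50 log units; beyond the scatter). Compound 3 `CC(=O)NCCCCNC(=O)c1[nH]c(C)c(C(=O)OC2CC3CCC2C3)c1C` differs from compound 2 by 2-acetamidoethyl in place of methoxy on a saturated chain carbon, two bonds along the chain from an amide-type nitrogen. Going by the values given here, no measured step covers this change; the single measured step, a 3.2-fold higher number from compound 1 to compound 2 (0.50 log units; beyond the scatter), concerned the ester-to-amide exchange and was modest. A chain of this kind is an open question here, so only a small weakening, or no step beyond the scatter, is expected. Compound 3 is therefore estimated at 500 nM, within 150 nM to 2000 nM, which means a 1.6-fold higher number from compound 2 to compound 3 (0.20 log units; within the scatter).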

Compound 3, half-maximal inhibitory concentration: 1000 nM
Compound 3: the middle estimate sits 2.0-fold (0.30 log units) below what was measured; the range from low to high includes it.
By their numbers in this assay, from the lowest: compound 1; then compound 2; then compound 3.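

Replacing methoxy with 2-acetamidoethyl on the amide side chain gives a 3.2-fold higher number from compound 2 to compound 3 (0.50 log units; beyond the scatter) in this assay, so this side chain still affects the read-out beyond the ester-to-amide exchange. Measured against the ester of compound 1, the (4-acetamidobutyl)amino group gives a 10-fold higher number from compound 1 to compound 3 (1.00 log units; beyond the scatter), the largest step among these compounds. No evidence here offers a reason for this weakening. The compounds shown leave open whether the longer chain or its acetamide end matters more, and how a plain butyl chain, an amine or a carboxylic acid would read here.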